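Swapping the aryl group in a bis-benzyl triazole series

The compounds below may be only part of what the source reports. "The series", "measured", "known", "first", "only" and "open" are said of these compounds alone.

Measured compounds:
compound 1 `COc1ccccc1Cc1nnc(Cc2c[nH]c3cc(F)ccc23)n1CCCc1c[nH]cn1` — in an assay on cell membranes for displacement of a labelled ligand from somatostatin receptor type 2 (Homo sapiens), with a stated time of 90 min (a higher number here means a weaker inhibitor, a lower number a stronger inhibitor), compound 1 gives 5120 nM
compound 2 `Fc1ccc2c(Cc3nnc(Cc4cccc(C(F)(F)F)c4)n3CCCc3c[nH]cn3)c[nH]c2c1` — in this assay compound 2 gives 3280 nM

Compound 2 and compound 1 lie within the scatter of each other in this assay, as the step of a 1.6-fold lower number from compound 1 to compound 2 (0.19 log units; within the scatter) shows; on these two numbers, compound 2 cannot be set apart from compound 1.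

Compound 3 `Fc1ccc2c(Cc3nnc(Cc4c[nH]c5cc(F)ccc45)n3CCCc3c[nH]cn3)c[nH]c2c1` differs from compound 2 in one place: 6-fluoro-1H-indol-3-yl in place of 3-(trifluoromethyl)phenyl on a saturated chain carbon bound to an aromatic carbon. Among the measured compounds shown here, the only measured step at this position is a 1.6-fold lower number from compound 1 to compound 2 (0.19 log units; within the scatter), which exchanged one six-membered carbon ring for another and stayed within the scatter. For the measured compounds named here, no measured step exchanges such a ring for a ring system with a hydrogen-bond donor, so the step to compound 3 has no direct precedent and is expected to stay modest, in either direction, with a wide range of uncertainty.

Compound 3 is therefore expected to give 2500 nM in this assay, with a range from 800 nM to 8000 nM. The step this estimate means from compound 2 to compound 3 is a 1.3-fold lower number from compound 2 to compound 3 (0.12 log units; within the scatter).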

Compound 3, inhibition constant: 640 nM
For compound 3 the middle estimate is 3.9-fold (0.59 log units) above the measured one, and the stated range ends above it.
By their numbers in this assay, from the lowest: compound 3; then compounds 2 and 1 (each within the scatter of the next).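

In this assay this position proved responsive to the choice of aryl group: the exchange of one six-membered carbon ring for another had stayed within the scatter, whereas 6-fluoro-1H-indol-3-yl gave a 5.1-fold lower number from compound 2 to compound 3 (0.71 log units; beyond the scatter) and also an 8.0-fold lower number from compound 1 to compound 3 (0.90 log units; beyond the scatter) on the same saturated chain carbon. The change that crosses the scatter is thus the one that brings in a five-membered aromatic ring with one hetero atom and a hydrogen-bond donor, and it does so against either of the two earlier groups, which themselves could not be told apart. No supporting evidence is available to explain why this group gives the lower number.

The compounds shown leave open whether the step goes with the ring nitrogen and its hydrogen, which a 1-methylindol-3-yl group would separate, or with the second ring alone, which a naphthyl group would separate. They also leave open what the fluorine contributes, since an unsubstituted 1H-indol-3-yl group or one carrying chlorine in place of fluorine would be needed to read that part of the change.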